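The source may hold more compounds than are shown below. What is called first, only, known or untested is meant among the compounds shown, and "the series" means these compounds.

Compound 2, with the structure `CCOC(=O)c1nc(NC(=O)c2ccc(F)cc2)nc2nn(C)cc12`, carries a fluorobenzamide on the shared core and a methyl on the ring nitrogen. In an assay on CHO cells for displacement of a labelled ligand from adenosine receptor A1 (Homo sapiens) (a lower number here means a stronger inhibitor, a higher number a weaker inhibitor), compound 2 gives only a limit, > 100000 nM, not a number. Compound 3, `CCOC(=O)c1nc(NC(=O)c2ccc(C)cc2)nc2nn(C)cc12`, likewise returns only a limit in this assay, > 100000 nM. The step from a step that the two limits leave unreadable from compound 2 to compound 3 therefore cannot be read, a point underlined by the limit of > 100000 nM in this assay, at which 2 of the 3 values shown sit. For the measured compounds named here, compound 1, `CCOC(=O)c1nc(N)nc2nn(CC(C)(C)C)cc12`, has a free amine and a neopentyl chain, and in this assay compound 1 gives 4000 nM; it differs from compound 2 in two places, so no single step links them.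

Compound 4, `CCOC(=O)c1nc(NC(=O)c2ccc(F)cc2)nc2nn(CC(C)(C)C)cc12`, is obtained from compound 2 by the change (tert-butyl in place of hydrogen on a saturated chain carbon bound to an aromatic nitrogen). Going by the values given here, no measured step reports this change on its own, so its size is unknown. Compound 2 sits at a limit in this assay. Compound 1, for its part, gives 4000 nM in this assay. Weighing both, the estimate for compound 4 is 50000 nM, spanning 5000 nM to 300000 nM. This estimate corresponds to an expected step of an at least 2.0-fold lower number from compound 2 to compound 4 (0.30 log units; that floor lies within the scatter), with a substantial chance that only a limit is reported again.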

Compound 4, inhibition constant: 2700 nM
Estimate against measurement, compound 4: 19-fold (1.27 log units) above; measured number below the stated range.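

In this assay, swapping the methyl on the ring nitrogen for a neopentyl chain gives an at least 37-fold lower number from compound 2 to compound 4 (1.56 log units; beyond the scatter), so this position strongly affects the reading when the fluorobenzamide is present. Adding the (4-fluorophenyl)carbonyl group to the free amine, with the neopentyl chain kept, gives a 1.5-fold lower number from compound 1 to compound 4 (0.17 log units; within the scatter), so the fluorobenzamide is compatible with a measurable value once that chain is present. Compound 2 gives only a limit, so the first step is a floor and its true size remains unknown: the limit of > 100000 nM in this assay, at which 2 of the 4 values shown sit.

As far as these compounds go, what remains open is whether the full neopentyl chain is needed, since an ethyl or a cyclohexylmethyl group at this position would test how much of the chain matters. From the compounds shown here alone, it is also open whether the methylbenzamide of compound 3 would respond in the same way to the neopentyl chain.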